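The source may hold more compounds than are shown below. What is called first, only, known or untested is meant among the compounds shown, and "the series" means these compounds.

Working notes on the series. Compound 2 `O=S(=O)(Nc1ccc2oc(-c3ccccc3)nc2c1)c1cccc(Cl)c1` carries a 3-chlorophenyl on the sulfonyl sulfur. In an assay on cells for inhibition of HSP60/HSP10 (Homo sapiens), with a stated time of 60 min (on this read-out higher numbers stand for weaker inhibition and lower numbers for stronger inhibition), compound 2 gives only a limit of the assay, > 100000 nM. Among the measured compounds shown here, compound 1 `O=S(=O)(Nc1ccc2oc(-c3ccccc3)nc2c1)c1ccc(Cl)cc1`, the 4-chlorophenyl analogue, is the only other measured member. In this assay compound 1 likewise gives a limit, > 100000 nM. For the measured compounds named here, the one measured step, a step that the two limits leave unreadable from compound 1 to compound 2, therefore cannot be read, since both ends sit at the limit of > 100000 nM in this assay, at which 2 of the 2 values shown sit.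

Compound 3 `O=S(=O)(Nc1ccc2oc(-c3ccccc3)nc2c1)c1ccccc1Cl` is to be measured in this assay. The change from compound 2 is 2-chlorophenyl in place of 3-chlorophenyl on a sulfonyl sulfur. Going by the values given here, no measured step bears on this move beyond the unreadable one between compound 1 and compound 2, so the two chlorophenyl isomers measured so far give neither a direction nor a size for moving the chlorine once more. The step expected in this assay is a number no higher from compound 2 to compound 3 (the limit leaves the size open), nothing beyond the scatter. Compound 3 is expected to give about 100000 nM in this assay, with a likely range from 30000 nM to 300000 nM, and most probably again reported only as a limit.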

Compound 3, half-maximal inhibitory concentration: > 100000 nM
Compound 3: no number, only a limit (the forecaster's own chance of this, stated with the estimate: 85%); the middle value lies on the limit itself.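

Compound 3, like compound 1 and compound 2, gives only a limit in this assay, so no step among these three chlorophenyl isomers can be read: the limit of > 100000 nM in this assay, at which 3 of the 3 values shown sit. The compounds shown leave open whether moving the chlorine changes inhibition at all, and at what concentration any of the three would reach half-maximal inhibition.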